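Swapping Nitro for Amino in Compound 3

The source may hold more compounds than are shown below. What is called first, only, known or untested is meant among the compounds shown, and "the series" means these compounds.

Values measured in a functional assay on HT-29 cells (Homo sapiens) for antiproliferative activity, read by MTT assay, with a stated time of 72 h (a higher number here means a weaker inhibitor, a lower number a stronger inhibitor), are as follows.
compound 1 `CCCCn1ccnc1-c1cc(OC)c(OC)c(OC)c1` gives > 100000 nM, which is a limit of the assay and not a number .
compound 2 `COc1cccc(-n2ccnc2-c2cc(OC)c(OC)c(OC)c2)c1` gives 18900 nM.
compound 3 `COc1ccc(C(=O)Nc2cc(OC)c(OC)c(OC)c2)cc1[N+](=O)[O-]` gives 8300 nM.

Compound 3 holds the lowest number of the set, and its gap to compound 2 lies beyond the usual scatter. That makes it the strongest inhibitor measured so far in this assay. Compound 4 `COc1ccc(C(=O)Nc2cc(OC)c(OC)c(OC)c2)cc1N` keeps all of compound 3 except one group, with amino in place of nitro on an aromatic carbon, ortho to a methoxy group and meta to a large group. The counted change is amino in place of nitro on an aromatic carbon.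

Among the compounds with values here, the only measured step is an at least 5.2-fold lower number from compound 1 to compound 2 (0.72 log units; beyond the scatter), with 3-methoxyphenyl in place of butyl on an aromatic nitrogen. Within the data shown here, it concerns another group on another core, and no measured step swaps nitro for amino. Among the measured compounds shown here, it shows only that a single swap in this set can move the number beyond the scatter. Starting from compound 3 at 8300 nM, a step of similar or smaller size is expected in this assay, more likely toward a lower number, meaning a stronger inhibitor, though the direction remains uncertain. The expected step is a 2.8-fold lower number from compound 3 to compound 4 (0.44 log units; beyond the scatter). For compound 4 the estimated value is 3000 nM, with an expected range from 600 nM to 15000 nM.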

Compound 4, half-maximal inhibitory concentration: > 100000 nM
Compound 4: only a limit was reported; the forecaster's own chance of this, stated with the estimate: 5%; middle value at least 33-fold (1.52 log units) away from the limit.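

In this assay, the position on this aromatic carbon, ortho to a methoxy group and meta to a large group, turns out to matter a great deal: amino in place of nitro gives an at least 12-fold higher number from compound 3 to compound 4 (1.08 log units; beyond the scatter). Within the data shown here, the earlier compounds offered only one readable step, an at least 5.2-fold lower number from compound 1 to compound 2 (0.72 log units; beyond the scatter), which concerned a group on an aromatic nitrogen of another core, whereas this step shows that a single swap can cost compound 3, the strongest inhibitor measured before it, nearly all its measurable activity. Compound 4 gives > 100000 nM, which is a limit of the assay and not a number, and the step carries that limit with it: the limit of > 100000 nM in this assay, at which 2 of the 4 values shown sit.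

At this position the compounds shown hold only nitro and amino, which leaves open whether the drop follows from gaining the amino group or from losing the nitro group. On these data alone, a fluorine, a methyl group or a plain hydrogen on that carbon would help to separate those two readings, and the part played by the neighbouring methoxy group, unchanged in this pair, stays open as well.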